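The compounds below may be only part of what the source reports. "The series", "measured", "known", "first", "only" and "open" are said of these compounds alone.

Of the compounds shown here, three sharing one core have been tested in a functional assay on THP-1 cells (Homo sapiens) for cytotoxicity, with a stated time of 72 h; on this read-out higher numbers stand for an effect only at larger amounts of compound and lower numbers for an effect already at smaller amounts. Compound 1 `CC(C)=CCC/C(C)=C/Cc1c(O)cc2c(c1O)C(=O)C[C@@H](c1cc(O)cc(O)c1)O2` gives 8500 nM in this assay. Compound 2 `CC(C)=CCC/C(C)=C/Cc1c(O)cc2c(c1O)C(=O)C[C@@H](c1ccc(O)c(O)c1)O2` gives in this assay only a limit of the assay, < 10000 nM. The step that the limit leaves unreadable from compound 1 to compound 2 is therefore not readable, which is what the limit of < 10000 nM in this assay, at which 1 of the 3 values shown sits, records. Compound 3 `C=C(C)C(O)CC/C(C)=C/Cc1c(O)cc2c(c1O)C(=O)C[C@@H](c1ccc(O)c(OC)c1)O2` likewise gives in this assay only a limit of the assay, > 10000 nM, as the limit of > 10000 nM in this assay, at which 1 of the 3 values shown sits, records, so compound 3 stands without a number of its own among the values shown. Compound 4 `COc1cc([C@@H]2CC(=O)c3c(cc(O)c(C/C=C(\C)C/C=C/C(C)(C)O)c3O)O2)ccc1O` has not been measured; it differs from compound 3 by 3-hydroxy-3-methylbut-1-en-1-yl in place of 2-hydroxy-3-methylbut-3-en-1-yl on a saturated chain carbon bound to a double-bonded chain carbon, the same atoms of the side chain joined differently. For the measured compounds named here, no measured step bears on this change, since the only step between measured compounds is unreadable. The expected step that the limit leaves unreadable from compound 3 to compound 4 is therefore none beyond the scatter. Compound 4 is estimated at 15000 nM in this assay, within a range from 6000 nM to 40000 nM, and is most likely to be reported again only as a limit.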

Compound 4, half-maximal effective concentration: > 10000 nM
Compound 4 gave a limit, no number; the forecaster's own chance of this, stated with the estimate: 70%; the middle value does not contradict the limit.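

Compound 3 and compound 4 both stand only as limits of the assay, so no step can be read from the change of side chain between them. The compounds shown leave open whether these two side chains differ at all in this assay.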